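The source may hold more compounds than are shown below. What is called first, only, known or untested is meant among the compounds shown, and "the series" means these compounds.

Among the measured compounds shown here, compound 1 `COc1ccc(-c2cc(/C=C/C(=O)c3ccc(N)cc3)[nH]n2)cc1` is one of two compounds measured here. In a functional assay on COLO 205 cells (Homo sapiens) for inhibition, read by sulforhodamine B assay, with a stated time of 48 h (on this read-out lower numbers stand for higher toxicity in this test and higher numbers for lower toxicity in this test), compound 1 gives 6410 nM. The second, compound 2 `COc1ccc(C(=O)/C=C/c2cc(-c3cc(OC)c(OC)c(OC)c3)n[nH]2)cc1`, gives 6060 nM in this assay. The two numbers lie within the usual scatter of repeated measurements, so the data give no ground to set one apart from the other; both sit in the same region of modest toxicity.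

Compound 3 `COc1ccc(-c2cc(/C=C/C(=O)c3ccc(N)cc3)[nH]n2)cc1OC` has not yet been measured. It differs from compound 1 by methoxy in place of hydrogen on an aromatic carbon, on the six-membered aromatic ring of carbon only, ortho to a methoxy group and meta to a large group. The core of compound 1 is kept.

For the measured compounds named here, no pair of measured compounds differs in only one place, so there is no earlier step to guide the size of this one. The change is small and adds a single acceptor, and the expectation is for a step from compound 1 to compound 3 of a 1.1-fold lower number from compound 1 to compound 3 (0.03 log units; within the scatter), that is, nothing beyond the scatter in either direction. Compound 3 is therefore expected to give about 6000 nM in this assay, in a range from 3000 nM to 12000 nM.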

Compound 3, concentration lethal to 50% of the cells: 6870 nM
Estimate against measurement, compound 3: 1.1-fold (0.06 log units) below; the range from low to high includes it.
By their numbers in this assay, from the lowest: compounds 2, 1 and 3 (each within the scatter of the next).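

In this assay, among the compounds shown here, methoxy in place of hydrogen on an aromatic carbon gives a 1.1-fold higher number from compound 1 to compound 3 (0.03 log units; within the scatter), and this is the first step in the set where two measured compounds differ in only one place. It shows that this position, ortho to a methoxy group and meta to a large group on the six-membered aromatic ring of carbon only, can take a second methoxy group, with its 2 heavy atoms and 1 hydrogen-bond acceptor, without a shift in the read-out beyond the scatter; the core of compound 1 keeps the same modest toxicity in this test with or without it. No measured information on the compounds offers an explanation for this result.

The compounds shown leave open whether a hydroxyl group, a chlorine atom or a longer chain such as ethoxy at this same place would also stay within the scatter. They also leave open what the methoxy group already present on this ring contributes, and whether a step at another place on the core of compound 1 would be larger.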